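The compounds below may be only part of what the source reports. "The series", "measured", "known", "first", "only" and "open" are said of these compounds alone.

Measured so far in this series:
- compound 1 `CN1CCC[C@H]1COc1cncc(-c2ccccc2)c1`: 0.11 nM
- compound 2 `CN1CCC[C@H]1COc1cncc(-c2cc(C(F)(F)F)cc(C(F)(F)F)c2)c1`: 2.4 nM

In an assay on membranes from brain for binding affinity to Neuronal acetylcholine receptor; alpha4/beta2 (Rattus norvegicus) (a higher number here means a weaker inhibitor, a lower number a stronger inhibitor), compound 1 gives 0.11 nM, the lower of the two numbers recorded. Compound 2 gives 2.4 nM in this assay, a gap from compound 1 that lies beyond the usual scatter. For the measured compounds named here, no step between compounds differing in a single place has been recorded, so the two values show only that the bis(trifluoromethyl)phenyl compound sits well above the phenyl compound.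

Compound 3 `CN1CCC[C@H]1COc1cncc(-c2cncnc2)c1` has not yet been measured. It differs from compound 1 by pyrimidin-5-yl in place of phenyl on an aromatic carbon. The change keeps the size of the group and its placement on the shared core, and adds two ring nitrogens. Going by the values given here, with no closely related step on record, the expected step from compound 1 to compound 3 is a 2.3-fold higher number from compound 1 to compound 3 (0.36 log units; beyond the scatter), toward a slightly higher number, at or near the scatter. Compound 3 is estimated at 0.25 nM, with a range from 0.06 nM to 1 nM.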

Compound 3, inhibition constant: 0.37 nM
Compound 3: the middle estimate sits 1.5-fold (0.17 log units) below what was measured; measured number inside the range.
By their numbers in this assay, from the lowest: compound 1; then compound 3; then compound 2.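

In this assay, the series now has its first step with a single change: pyrimidin-5-yl in place of phenyl, on an aromatic carbon two atoms from the ring nitrogen, gives a 3.4-fold higher number from compound 1 to compound 3 (0.53 log units; beyond the scatter). This step is modest but beyond the scatter, so at this position, replacing phenyl with a ring of the same heavy-atom count that adds two hydrogen-bond acceptors costs some affinity without removing it. No measurement on record accounts for the size of this step.

The compounds shown leave open whether a pyridin-3-yl group, with a single extra ring nitrogen, would fall nearer compound 1 or compound 3. They also leave open how a phenyl ring carrying one amine or one nitrile would compare with the unsubstituted phenyl of compound 1.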